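This account rests on a few compounds, and the source may have more. Where it says the series, first, only, none or still open, it means among the compounds named here.

Three analogues share one core. Compound 1 `O=C(Nc1cccc(OCc2cn(-c3ccccc3)nn2)c1)Nc1ccc(Cl)c(C(F)(F)F)c1` bears hydrogen on the aromatic carbon where compound 2 `CCc1cccc(-n2cc(COc3cccc(NC(=O)Nc4ccc(Cl)c(C(F)(F)F)c4)c3)nn2)c1` bears ethyl and compound 3 `CC(C)c1cccc(-n2cc(COc3cccc(NC(=O)Nc4ccc(Cl)c(C(F)(F)F)c4)c3)nn2)c1` bears isopropyl. In a functional assay on HepG2 cells (Homo sapiens) for inhibition, read by MTT assay, with a stated time of 72 h (a lower number here means a stronger inhibitor, a higher number a weaker inhibitor), compound 1 gives 1780 nM, compound 2 gives 37900 nM and compound 3 gives 3250 nM, the second highest of the three numbers. The measured steps are a 21-fold higher number from compound 1 to compound 2 (1.33 log units; beyond the scatter), a 1.8-fold higher number from compound 1 to compound 3 (0.26 log units; within the scatter) and a 12-fold lower number from compound 2 to compound 3 (1.07 log units; beyond the scatter). Compound 4 `O=C(Nc1cccc(OCc2cn(-c3ccccc3I)nn2)c1)Nc1ccc(Cl)c(C(F)(F)F)c1` differs from compound 3 by 2-iodophenyl in place of 3-isopropylphenyl on an aromatic nitrogen. Within the data shown here, no measured compound carries iodine, so these steps show only that substitution of this ring can move this assay strongly, without fixing a direction. For compound 4 a step of about a 1.1-fold lower number from compound 3 to compound 4 (0.03 log units; within the scatter) is expected. The estimate for compound 4 is 3000 nM, between 600 nM and 15000 nM.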

Compound 4, half-maximal inhibitory concentration: 2870 nM
Compound 4: middle estimate off by 1.0-fold (0.02 log units), on the high side; measured number inside the range.
By their numbers in this assay, from the lowest: compounds 1, 4 and 3 (each within the scatter of the next); then compound 2.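

Read in this assay the 2-iodophenyl group on the aromatic nitrogen matches 3-isopropylphenyl within the scatter (a 1.1-fold lower number from compound 3 to compound 4 (0.05 log units; within the scatter)), and iodo in place of hydrogen likewise stays within the scatter (a 1.6-fold higher number from compound 1 to compound 4 (0.21 log units; within the scatter)). Compound 2 alone stands apart (a 13-fold lower number from compound 2 to compound 4 (1.12 log units; beyond the scatter)), so a substituent on this ring need not move the number, and the large shift among these four belongs to 3-ethylphenyl only. Nothing shown accounts for compound 2 standing apart.

Still open, from the compounds shown here alone, is whether 3-iodophenyl or 4-iodophenyl would hold this level, and whether an amine or a carboxylic acid on this ring would move the number in either direction.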